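The source may report more compounds than this note shows. Statements on the series, on what has been measured and on what is new or still open speak of the compounds shown alone.

Measured in a toxicity assay on CHO cells (Cricetulus griseus) for cytotoxicity, read by WST assay, with a stated time of 24 h; on this read-out lower numbers stand for stronger inhibition and higher numbers for weaker inhibition:
- Compound 1 `CC(C)=CCCC(C)=CCNCCCN`: > 150000 nM
- Compound 2 `CC(C)=CCCC(C)=CCNCCCN1CCCC1`: > 150000 nM
- Compound 3 `CC(C)=CCCC(C)=CCNCCCN1CCCC1=O`: > 150000 nM

Each of these values is a limit of the assay, not a number. Compound 3 stands at the limit of > 150000 nM in this assay, at which 3 of the 3 values shown sit.

Compound 4 `CC(C)=CCCC(C)=CCNCCCN(C)CCCN` carries (3-aminopropyl)(methyl)amino in place of 2-oxopyrrolidin-1-yl, on a saturated chain carbon, three bonds along the chain from an amine nitrogen: (3-aminopropyl)(methyl)amino in place of 2-oxopyrrolidin-1-yl on a saturated chain carbon, three bonds along the chain from an amine nitrogen.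

The measured changes at this same place are a step that the two limits leave unreadable from compound 1 to compound 2, a step that the two limits leave unreadable from compound 1 to compound 3 and a step that the two limits leave unreadable from compound 2 to compound 3. None of them has a readable size, so they point to no direction, and no step beyond the usual scatter is expected. The expected change is a number no higher from compound 3 to compound 4 (the limit leaves the size open). For compound 4 the estimated value is 150000 nM, with an expected range of 50000 nM to 300000 nM.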

Compound 4, half-maximal inhibitory concentration: > 150000 nM
Compound 4 ended at the assay's limit (the forecaster's own chance of this, stated with the estimate: 60%); the middle value sits exactly at the limit.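

No step can be read from compound 1, compound 2 or compound 3 to compound 4, since all four values are limits, not numbers: the limit of > 150000 nM in this assay, at which 4 of the 4 values shown sit.

The compounds shown leave open how strongly any of them inhibits these cells, and whether swapping these groups changes that at all.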